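Aryl amide swap on the pyridylmethyl series

The compounds below may be only part of what the source reports. "The series", "measured", "known", "first", "only" and "open" are said of these compounds alone.

Compound 1 `O=C(CN1CCN(c2nnc(Cc3ccncc3)c3ccccc23)CC1)Nc1cccc(F)c1` gives 4.4 nM in a functional assay on MDA-MB-231 cells (Homo sapiens) for cytotoxicity, read by MTT assay, with a stated time of 72 h (on this read-out higher numbers stand for weaker inhibition and lower numbers for stronger inhibition), the lowest of the two numbers recorded. Within the data shown here, compound 2 `O=C(CN1CCN(c2nnc(Cc3ccccc3)c3ccccc23)CC1)Nc1cccc(Br)c1` differs from compound 1 in two places, and no single-change step connects the pair. In this assay compound 2 gives 3880 nM. Compound 3 `O=C(CN1CCN(c2nnc(Cc3ccncc3)c3ccccc23)CC1)Nc1cc(C(F)(F)F)ccc1Cl` carries 2-chloro-5-(trifluoromethyl)phenyl in place of 3-fluorophenyl on an amide-type nitrogen. Going by these compounds, without a measured step for such a change, the direction is open; a moderate rise in the number is expected, since compound 1 already gives 4.4 nM and the far heavier aryl group is untested. Compound 3 is estimated at 30 nM, range 4 nM to 300 nM, a step of a 6.8-fold higher number from compound 1 to compound 3 (0.83 log units; beyond the scatter).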

Compound 3, half-maximal inhibitory concentration: 3.7 nM
For compound 3 the middle estimate is 8.1-fold (0.91 log units) above the measured one, and the stated range ends above it.
By their numbers in this assay, from the lowest: compounds 3 and 1 (each within the scatter of the next); then compound 2.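

On the amide-type nitrogen, 2-chloro-5-(trifluoromethyl)phenyl replaces 3-fluorophenyl with a 1.2-fold lower number from compound 1 to compound 3 (0.08 log units; within the scatter) in this assay. Among these compounds, this is the only single-change step read so far, and it shows that a larger aryl group, with 11 heavy atoms against 7, can stand here with no change beyond the scatter. Nothing measured here bears on this result.

Still open, going by these compounds, is how an aryl group carrying a carboxylic acid or a dimethylamino group would read at this nitrogen. The two changes separating compound 2 from compound 1 also cannot be read apart.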